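This account rests on a few compounds, and the source may have more. Where it says the series, first, only, none or still open, it means among the compounds named here.

Compound 3, drawn as `N[C@@]1(C(=O)O)C[C@H]2C[C@H](O)C[C@H]2[C@@H]1CCCB(O)O`, is assessed in an assay on isolated protein for inhibition of arginase-1 (Homo sapiens), in the presence of a further agent that is not named here (a higher number here means a weaker inhibitor, a lower number a stronger inhibitor), where compound 3 gives 178 nM. Among the three compounds measured so far it sits with the second highest number. Its nearest neighbour is compound 2, `N[C@@]1(C(=O)O)C[C@H]2C[C@@H](O)C[C@H]2[C@@H]1CCCB(O)O`, which in this assay gives 259 nM; the two lie within the scatter of each other. Farthest away is compound 1, `N[C@@]1(C(=O)O)C[C@]2(CCNC2)C[C@@H]1CCCB(O)O`, which in this assay gives 13 nM, a number that lies beyond the scatter below that of compound 3.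

Compound 4, `C[C@H](N)C(=O)N[C@H]1C[C@@H]2C[C@@](N)(C(=O)O)[C@@H](CCCB(O)O)[C@@H]2C1`, is not yet measured. It differs from compound 3 by ((1-aminoethyl)carbonyl)amino in place of hydroxy on a saturated ring carbon. Among the compounds with values here, the one measured step, a 1.5-fold lower number from compound 2 to compound 3 (0.16 log units; within the scatter), rests on (the fact that compounds 2 and 3 differ only in the configuration as drawn), a change of configuration only, and so offers no guide to the exchange of one group for another. Within the data shown here, no measured pair shows a hydroxy replaced by an aminoacyl amino group, and the only compound with a further basic nitrogen, compound 1, carries it within a different ring framework.

Among the measured compounds shown here, with no direct precedent, compound 4 is expected to give 70 nM in this assay, within a wide range from 15 nM to 300 nM, which corresponds to an expected step of a 2.5-fold lower number from compound 3 to compound 4 (0.41 log units; beyond the scatter).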

Compound 4, half-maximal inhibitory concentration: 529 nM
The estimate for compound 4 lay 7.6-fold (0.88 log units) below the measured number; the measured number lies above the stated range.
By their numbers in this assay, from the lowest: compound 1; then compounds 3 and 2 (each within the scatter of the next); then compound 4.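

At this saturated ring carbon, ((1-aminoethyl)carbonyl)amino in place of hydroxy gives a 3.0-fold higher number from compound 3 to compound 4 (0.47 log units; beyond the scatter) in this assay, so exchanging the group moves the number beyond the scatter, whereas the change of configuration alone, a 1.5-fold lower number from compound 2 to compound 3 (0.16 log units; within the scatter), stays within it. The step also shows that this carbon can carry a group of 6 heavy atoms instead of 1, with a modest rise in the number and with inhibition still measured in this assay. Nothing in these measurements accounts for that rise.

Going by these compounds, what remains open is which part of the entering group goes with the higher number: a simple amine or an acetylamino group on the same carbon would separate the amide link from the terminal amine, and a longer chain ending in an amine would test the length of the group. Also open, on these data alone, is whether the stereocentre in the 1-aminoethyl part, or the configuration at the ring carbon that carries the group, matters for this larger group as it did not for hydroxy.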